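Moving the amine outward in a biphenyl amide series

A few compounds are considered here, and "the series" means these few. Any claim that something is new, unique, unknown or untested is made for them only; others in the source may bear on it.

Compound 1 `CC(C)C[C@H](N)CN(C(=O)C(C)Cc1ccccc1)c1ccc(-c2ccccc2)cc1` gives 1.2 nM in a functional assay for agonist activity at G protein-coupled receptor 88 (Homo sapiens), read by HTRF and cAMP accumulation; a lower number here means that less compound is needed, a higher number that more compound is needed for the effect. Compound 2 `CC(C)CCCN(C(=O)[C@@H]1C[C@H]1c1ccccc1)c1ccc(-c2ccccc2)cc1` reaches only a limit in this assay, > 100 nM. Compound 3 `CC(C)[C@H](N)CN(C(=O)[C@@H]1C[C@H]1c1ccccc1)c1ccc(-c2ccccc2)cc1` gives 1.1 nM in this assay.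

Compound 3 and compound 1 differ only within the usual scatter; compound 2 gives no number at all. Compound 4 `CC(C)CCNCCN(C(=O)[C@@H]1C[C@H]1c1ccccc1)c1ccc(-c2ccccc2)cc1` is not yet measured. It differs from compound 3 by (isopentylamino)methyl in place of 1-amino-2-methylpropyl on a saturated chain carbon bound to an amide-type nitrogen. Within the data shown here, one measured step bears on this: an at least 90-fold lower number from compound 2 to compound 3 (1.95 log units; beyond the scatter), a large gain when the amine entered. Compound 4 keeps an amine, but carries it one bond further out and on a longer branch, so a partial loss is expected, a 14-fold higher number from compound 3 to compound 4 (1.13 log units; beyond the scatter). Compound 4 is therefore estimated at 15 nM, within 2 nM to 150 nM.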

Compound 4, half-maximal effective concentration: 5.1 nM
Compound 4: middle estimate off by 2.9-fold (0.47 log units), on the high side; measured number inside the range.
By their numbers in this assay, from the lowest: compounds 3 and 1 (each within the scatter of the next); then compound 4. At a limit, above all of these: compound 2.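

An amine still works when it sits inside the chain as isopentylamino rather than on a branch: the result is an at least 19-fold lower number from compound 2 to compound 4 (1.29 log units; beyond the scatter). The change from 1-amino-2-methylpropyl to (isopentylamino)methyl does have a cost, though: a 4.6-fold higher number from compound 3 to compound 4 (0.67 log units; beyond the scatter). The comparison with compound 2 rests on a limit, not a number: the limit of > 100 nM in this assay, at which 1 of the 4 values shown sits.

The change alters the amine's place, the group's size and the defined stereocentre together, and the compounds shown do not separate these. Also open, on these data alone, is how a carboxylic acid in place of the amine would read.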